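Aryl variation on the shared core: lipophilicity working notes

This account rests on a few compounds, and the source may have more. Where it says the series, first, only, none or still open, it means among the compounds named here.

Compound 3 `CC(=O)c1ccc(-c2cn3ccnc3c(-c3ccc4ncn(C5CCCCC5)c4c3)n2)cc1` gives 2.06 in a physicochemical assay for lipophilicity, using the shake flask method, in phosphate buffer, measured as octanol-water partition, with a stated time of 85 min, at pH 7.4 (on this read-out higher numbers stand for higher lipophilicity and lower numbers for lower lipophilicity), and stands highest of the three measured numbers. Compound 2 `Cc1cccc(-c2cn3ccnc3c(-c3ccc4ncn(C5CCCCC5)c4c3)n2)c1` gives 1.87, and the step of a number 0.19 log units higher from compound 2 to compound 3 (within the scatter) is within the scatter. Compound 1 `c1cn2cc(-c3ccsc3)nc(-c3ccc4ncn(C5CCCCC5)c4c3)c2n1` gives 1.81, with a number 0.25 log units higher from compound 1 to compound 3 (within the scatter) and a number 0.06 log units higher from compound 1 to compound 2 (within the scatter) likewise within the scatter. Compound 4 `COc1ccccc1-c1cn2ccnc2c(-c2ccc3ncn(C4CCCCC4)c3c2)n1` carries the change (2-methoxyphenyl in place of 4-acetylphenyl on an aromatic carbon). All three aryl exchanges measured so far moved this assay by less than the scatter, so no step beyond the scatter is expected here, and the step of a number 0.11 log units lower from compound 3 to compound 4 (within the scatter) is an estimate only. For compound 4 the expected value is 1.95, with a range from 1.65 to 2.25.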

Compound 4, partition coefficient: 1.72
Beside the measured number, compound 4's estimate is 0.23 log units above it; the measured number falls inside the stated range.
By their numbers in this assay, from the lowest: compounds 4, 1, 2 and 3 (each within the scatter of the next, the first and the last beyond it).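

In this assay, for the compounds shown here, the step of a number 0.34 log units lower from compound 3 to compound 4 (beyond the scatter) is the first aryl exchange at this position to pass the scatter, though only modestly. The steps of a number 0.15 log units lower from compound 2 to compound 4 (within the scatter) and a number 0.09 log units lower from compound 1 to compound 4 (within the scatter) stay within it, so the separation holds only between 2-methoxyphenyl and 4-acetylphenyl. No supporting data bear on what underlies this separation.

Still open, from the compounds shown here alone, is whether the gap follows the group itself or its place on the phenyl ring. Also open, going by these compounds, is how far an amine or a carboxylic acid here would shift the number.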